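Ethynyl in place of 1-benzofuran-2-yl: what to expect

This account rests on a few compounds, and the source may have more. Where it says the series, first, only, none or still open, it means among the compounds named here.

Measured in a functional assay on K562 cells (Homo sapiens), read by MTT assay, with a stated time of 72 h; a lower number here means a stronger inhibitor, a higher number a weaker inhibitor:
Compound 1 `COc1nc(N)nc2c1c(-c1ccsc1)cn2[C@@H]1O[C@H](CO)[C@@H](O)[C@H]1O`: > 20000 nM (a limit)
Compound 2 `COc1nc(N)nc2c1c(-c1cc3ccccc3o1)cn2[C@@H]1O[C@H](CO)[C@@H](O)[C@H]1O`: 15500 nM

Going by the values given here, compound 2, at 15500 nM, holds the only actual number in this assay. The other result is a limit: compound 1 stands at > 20000 nM.

The next compound to be tested is compound 3 `C#Cc1cn([C@@H]2O[C@H](CO)[C@@H](O)[C@H]2O)c2nc(N)nc(OC)c12`. The change is ethynyl in place of 1-benzofuran-2-yl on an aromatic carbon. Among the compounds with values here, one measured step bears on it, a swap at the same carbon: an at least 1.2-fold lower number from compound 1 to compound 2 (0.11 log units; that floor lies within the scatter). That step rests on a limit, and both groups in it contain a ring, whereas ethynyl has none. It therefore gives only weak guidance on the size of the coming change.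

No clear step beyond the scatter is expected in this assay, though a result reported only as a limit would be no surprise. The expected step is a 1.3-fold lower number from compound 2 to compound 3 (0.11 log units; within the scatter). For compound 3 the estimated value is 12000 nM, with an expected range of 2500 nM to 30000 nM.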

Compound 3, half-maximal inhibitory concentration: > 20000 nM
Compound 3: only a limit was reported; the forecaster's own chance of this, stated with the estimate: 45%; at least 1.6-fold (0.22 log units) between middle value and limit.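

In this assay, replacing 1-benzofuran-2-yl with ethynyl, a group with no ring, gives an at least 1.2-fold higher number from compound 2 to compound 3 (0.11 log units; that floor lies within the scatter), so this result does not establish a real difference between the two groups at this carbon. Compound 3 gives > 20000 nM, which is a limit, and the step between compound 1 and compound 3 cannot be read because both results are limits. With ethynyl added to the two ring-bearing groups, this carbon of the five-membered aromatic ring has now carried three different groups, yet compound 2 alone has an actual number, and the series mostly sits at the same limit: the limit of > 20000 nM in this assay, at which 2 of the 3 values shown sit.

The compounds shown leave open whether any group at this carbon can produce a value clearly apart from that of compound 2, at 15500 nM. An amine, a carboxylic acid or a longer chain in place of ethynyl could test this, and a measured number for such a compound would show whether this position can shift the result in this assay at all.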